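Adding a methyl to the benzyl group of compound 3

The source may hold more compounds than are shown below. What is called first, only, known or untested is meant among the compounds shown, and "the series" means these compounds.

compound 1 `CN(C)CCCCNc1nc2cc([N+](=O)[O-])ccc2nc1NCc1ccc(C(F)(F)F)cc1`: 9.73 ug/mL
compound 2 `O=[N+]([O-])c1ccc2nc(NCc3ccc(C(F)(F)F)cc3)c(N3CCNCC3)nc2c1`: 9.61 ug/mL
compound 3 `CN(C)CCCNc1nc2cc([N+](=O)[O-])ccc2nc1NCc1ccccc1`: 2.74 ug/mL

In an ADME assay on HEK293 cells (Homo sapiens) for cytotoxicity, read by MTT assay, with a stated time of 24 h (a higher number here means a weaker inhibitor, a lower number a stronger inhibitor), compound 3 gives the lowest number of the three, 2.74 ug/mL. Compound 4 `Cc1ccc(CNc2nc3ccc([N+](=O)[O-])cc3nc2NCCCN(C)C)cc1` is the next to be tested. It differs from compound 3 by one change, methyl in place of hydrogen on an aromatic carbon, turning benzyl into 4-methylbenzyl.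

For the measured compounds named here, the only measured single-place step is a 1.0-fold lower number from compound 1 to compound 2 (0.01 log units; within the scatter). It lies within the scatter, but it sits elsewhere on the molecule and says little about this change. Compound 1 and compound 2 carry a trifluoromethyl group that compound 3 lacks, yet they also differ from it in other places, so their higher numbers cannot be pinned on that group. Going by the values given here, with no measured step for a methyl, only a small change is expected. The expected step is a 1.2-fold higher number from compound 3 to compound 4 (0.08 log units; within the scatter), which would stay within the scatter. For compound 4 the estimated value is 3.3 ug/mL, with an expected range of 1.5 ug/mL to 7.5 ug/mL.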

Compound 4, half-maximal inhibitory concentration: 15.8 ug/mL
Beside the measured number, compound 4's estimate is 4.8-fold (0.68 log units) below it; measured number above the stated range.
By their numbers in this assay, from the lowest: compound 3; then compounds 2, 1 and 4 (each within the scatter of the next).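

In this assay, one methyl on an aromatic carbon, para to a large group, is not a neutral addition: turning benzyl into 4-methylbenzyl gives a 5.8-fold higher number from compound 3 to compound 4 (0.76 log units; beyond the scatter) and so weakens the inhibitor. The only other single-place step shown, a 1.0-fold lower number from compound 1 to compound 2 (0.01 log units; within the scatter), lies elsewhere on the molecule and within the scatter, so this benzyl ring is the one place shown where a small edit clearly moves the number. Nothing measured here indicates why a single added carbon has this effect.

Whether the step is particular to methyl stays open, as no fluorine, chlorine or methoxy group is shown at the same place. Compound 1 and compound 2 carry trifluoromethyl on the benzyl group, but each also differs from compound 4 elsewhere, so neither settles the question.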